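Adding One Fluoro to Compound 2

The compounds below may be only part of what the source reports. "The series", "measured", "known", "first", "only" and "open" are said of these compounds alone.

Going by the values given here, in an ADME assay on HEK293 cells (Homo sapiens) for cytotoxicity, read by MTT assay, with a stated time of 24 h (on this read-out higher numbers stand for weaker inhibition and lower numbers for stronger inhibition), compound 1 (`COC(=O)c1scc(-c2ccc(NC(=O)c3ccccn3)cc2)c1OC`) has the entry "not determined" (no result reported), while compound 2 (`COC(=O)c1scc(-c2ccc(NC(=O)c3cccc(I)c3)cc2)c1OC`) gives 42700 nM, the only number available so far. Compound 3 (`COC(=O)c1scc(-c2ccc(NC(=O)c3cc(I)ccc3F)cc2)c1OC`) awaits measurement and differs from compound 2 by a single change: fluoro in place of hydrogen on an aromatic carbon. In short, this is fluoro in place of hydrogen on an aromatic carbon. Among the compounds with values here, no measured pair of compounds shows the effect of such a change here. The expected result is a 1.1-fold lower number from compound 2 to compound 3 (0.03 log units; within the scatter), a step estimated to stay within the usual scatter, with no clear direction. Compound 3 is estimated at 40000 nM, within a range of 15000 nM to 100000 nM.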

Compound 3, half-maximal inhibitory concentration: 45300 nM
The estimate for compound 3 lay 1.1-fold (0.05 log units) below the measured number; low and high end bracket the measured number.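

In this assay, placing fluoro on this aromatic carbon, ortho to a large group and para to the iodo group, gives a 1.1-fold higher number from compound 2 to compound 3 (0.03 log units; within the scatter). Going by these compounds alone, this is the first measured step at this position, and it shows that this carbon can carry a fluoro with no readable shift in the number, though that rests on this single pair. On these data alone, whether a chloro, a methoxy or an amine on the same carbon would also leave the number in place stays open. Nothing available explains why the fluoro leaves the number where it is.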